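The source may hold more compounds than are shown below. What is called first, only, known or untested is meant among the compounds shown, and "the series" means these compounds.

Measured so far in an assay on a protein complex for inhibition of CDK8/Cyclin C (Homo sapiens), with a stated time of 1 h; a higher number here means a weaker inhibitor, a lower number a stronger inhibitor:

Compound 1, `CNC(=O)/C=C/c1ccncc1-c1ccc2ccccc2c1`: 12.4 nM
Compound 2, `CN(C)C(=O)/C=C/c1ccncc1-c1ccc2ccccc2c1`: 30.1 nM

Among these two numbers compound 2 gives the highest one in this assay. Within the data shown here, its only neighbour is compound 1, and the single step between them is a 2.4-fold higher number from compound 1 to compound 2 (0.39 log units; beyond the scatter), a methyl in place of a hydrogen on the amide-type nitrogen.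

Compound 3, `O=C(/C=C/c1ccncc1-c1ccc2ccccc2c1)NC1CC1`, has not yet been measured in this assay. It differs from compound 2 in one place: cyclopropylamino in place of dimethylamino on a carbonyl carbon. Among the measured compounds shown here, the one measured step that bears on this change is a 2.4-fold higher number from compound 1 to compound 2 (0.39 log units; beyond the scatter), in which the hydrogen on the amide nitrogen of compound 1 was replaced by a methyl and the number rose. Compound 3 puts a hydrogen back on that nitrogen, with a cyclopropyl in place of the remaining methyl, so the hydrogen-bond donor that compound 1 has and compound 2 lacks is present again. A step back toward compound 1 is therefore expected, modest in size, in the direction of a lower number. Compound 3 is estimated at 13 nM in this assay, with a range from 6 nM to 30 nM. The expected step is a 2.3-fold lower number from compound 2 to compound 3 (0.36 log units; beyond the scatter).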

Compound 3, half-maximal inhibitory concentration: 40.1 nM
Beside the measured number, compound 3's estimate is 3.1-fold (0.49 log units) below it, outside the stated range (above it).
By their numbers in this assay, from the lowest: compound 1; then compounds 2 and 3 (each within the scatter of the next).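

In this assay, restoring a hydrogen on the amide-type nitrogen does not by itself separate the new compound from the tertiary amide: the step is a 1.3-fold higher number from compound 2 to compound 3 (0.12 log units; within the scatter), so cyclopropylamino and dimethylamino on this carbonyl carbon cannot be told apart here, although the first carries a hydrogen-bond donor and the second none. The group left on the nitrogen therefore matters as well, since exchanging methyl for cyclopropyl while the amide hydrogen stays gives a 3.2-fold higher number from compound 1 to compound 3 (0.51 log units; beyond the scatter), and among these three compounds the methylamide, compound 1, alone stands clear of the other two. Nothing available here accounts for this result.

The compounds shown leave open how an ethyl, an isopropyl or a cyclobutyl on the same nitrogen would read, and so whether cyclopropyl is a special case or part of a wider trend among secondary amides. They also leave open whether the primary amide, with two hydrogens on that nitrogen, or a cyclic tertiary amide such as a morpholine amide, would fall nearer compound 1 or nearer compound 2 and compound 3.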